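Diaryl Urea Pair: Swapping Trifluoromethyl for a Second Chloro

The source may hold more compounds than are shown below. What is called first, only, known or untested is meant among the compounds shown, and "the series" means these compounds.

Measured compounds:
compound 1, `COc1cc2cc(Oc3ccc(NC(=O)Nc4cccc(C(F)(F)F)c4)cc3)c(C)nc2cc1OC`: 29700 nM
compound 2, `COc1cc2cc(Oc3ccc(NC(=O)Nc4ccc(Cl)c(C(F)(F)F)c4)cc3)c(C)nc2cc1OC`: 10700 nM

Of the compounds shown here, two sharing one core have been tested in a functional assay on A498 cells (Homo sapiens) for inhibition, read by sulforhodamine B assay, with a stated time of 48 h; on this read-out lower numbers stand for higher toxicity in this test and higher numbers for lower toxicity in this test. Compound 1 gives 29700 nM, and compound 2 gives 10700 nM. Among the measured compounds shown here, the single step between them, a 2.8-fold lower number from compound 1 to compound 2 (0.44 log units; beyond the scatter), is the only structure-to-number relation available. On the numbers shown, compound 2 stands at the lowest value of the two, with compound 1 as its nearest neighbour.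

Compound 3, `COc1cc2cc(Oc3ccc(NC(=O)Nc4ccc(Cl)c(Cl)c4)cc3)c(C)nc2cc1OC`, has not yet been measured. It differs from compound 2 in one place: chloro in place of trifluoromethyl on an aromatic carbon. For the measured compounds named here, no measured step bears directly on this exchange; the one step recorded concerns a chloro entering in place of hydrogen, not a chloro replacing a trifluoromethyl, so it offers only a loose guide to scale. With nothing pointing firmly either way, a step in this assay that stays within the usual scatter is expected, with at most a small drift toward a higher number; the expected step is a 1.4-fold higher number from compound 2 to compound 3 (0.15 log units; within the scatter). Compound 3 is therefore estimated at 15000 nM, with a plausible range from 5000 nM to 45000 nM.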

Compound 3, concentration lethal to 50% of the cells: 74900 nM
For compound 3 the middle estimate is 5.0-fold (0.70 log units) below the measured one; the measured number lies above the stated range.
By their numbers in this assay, from the lowest: compound 2; then compound 1; then compound 3.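

The result shows that the place ortho to a chloro group is sensitive to which group it carries: in this assay, exchanging trifluoromethyl for chloro there gives a 7.0-fold higher number from compound 2 to compound 3 (0.85 log units; beyond the scatter), so the two groups cannot be treated as interchangeable in this series. The dichloro compound also stands apart from the compound lacking the ring chloro, with a 2.5-fold higher number from compound 1 to compound 3 (0.40 log units; beyond the scatter), so the lower number seen on adding a chloro to the trifluoromethyl-bearing ring, a 2.8-fold lower number from compound 1 to compound 2 (0.44 log units; beyond the scatter), does not carry over to the 3,4-dichlorophenyl group; among the three compounds, the low number appears only where chloro and trifluoromethyl stand together. Among the compounds shown here, nothing given here explains why this exchange moves the number so far in this direction.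

The compounds shown leave open whether a bromo, a methyl or a nitrile at this place would stay near compound 2 or move toward compound 3. They also leave open whether the order of the three compounds would hold in any cell line other than the one tested here.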